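Phenyl replaces trifluoromethyl on the sulfonyl group of compound 3

This account rests on a few compounds, and the source may have more. Where it says the series, first, only, none or still open, it means among the compounds named here.

Among the measured compounds shown here, compound 3 `CN(CCn1cc[n+](C)c1/C=N/O)S(=O)(=O)C(F)(F)F` gives -1.5 in a physicochemical assay for lipophilicity (on this read-out lower numbers stand for lower lipophilicity and higher numbers for higher lipophilicity), the highest of the two numbers so far. Its closest relative, compound 2 `CN(CCn1cc[n+](C)c1/C=N/O)S(C)(=O)=O`, gives -3.31. Compound 1 `C[n+]1ccn(COCC[N+](=O)[O-])c1/C=N/O` has no result reported in this assay. For the measured compounds named here, only one measured step bears on the new compound: a number 1.81 log units higher from compound 2 to compound 3 (beyond the scatter), a large move from one group on the sulfonyl sulfur to another. Compound 4 `CN(CCn1cc[n+](C)c1/C=N/O)S(=O)(=O)c1ccccc1` carries a further change at that same spot, (phenyl in place of trifluoromethyl on a sulfonyl sulfur). Going by the values given here, the single step seen suggests that a swap there can shift this assay strongly, so compound 4 is expected to land a number 0.50 log units higher from compound 3 to compound 4 (beyond the scatter). Compound 4 is therefore estimated at -1, within a range of -1.8 to -0.3.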

Compound 4, distribution coefficient: -1.72
Compound 4: the middle estimate sits 0.72 log units above what was measured; the measured number falls inside the stated range.
By their numbers in this assay, from the lowest: compound 2; then compounds 4 and 3 (each within the scatter of the next).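

On the sulfonyl sulfur, phenyl and trifluoromethyl cannot be told apart in this assay and the data give a number 0.22 log units lower from compound 3 to compound 4 (within the scatter) for this swap. Replacing methyl with phenyl gives a number 1.59 log units higher from compound 2 to compound 4 (beyond the scatter) as a large step, so among these three groups methyl is the one that stands apart, even though phenyl and trifluoromethyl share little in atoms or ring content. No measurement shown explains this. As far as these compounds go, whether a longer alkyl chain, or a phenyl ring carrying an amine, would stay with phenyl or drop towards methyl remains open.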